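The source may hold more compounds than are shown below. What is called first, only, known or untested is meant among the compounds shown, and "the series" means these compounds.

In a functional assay for inhibition of sodium/hydrogen exchanger (Oryctolagus cuniculus) (a lower number here means a stronger inhibitor, a higher number a weaker inhibitor), compound 2 `Cc1cc(Oc2ccc(Cl)cc2)c(S(C)(=O)=O)cc1C(=O)N=C(N)N` gives 13 nM, the lower of the two numbers recorded, though within the scatter of compound 1 `Cc1cc(C2CCCCC2)c(S(C)(=O)=O)cc1C(=O)N=C(N)N`, which gives 22 nM; the step of a 1.7-fold lower number from compound 1 to compound 2 (0.23 log units; within the scatter) is small. Compound 3 `Cc1cc(N2CCCCC2)c(S(C)(=O)=O)cc1C(=O)N=C(N)N` differs from compound 2 by piperidin-1-yl in place of 4-chlorophenoxy on an aromatic carbon. Within the data shown here, only the step from compound 1 to compound 2 bears on this change, one ring replacing another on the same aromatic carbon, and it stayed within the scatter. Since the incoming group is again a six-membered ring, a step of a 1.7-fold higher number from compound 2 to compound 3 (0.23 log units; within the scatter) is expected, not beyond the scatter. Compound 3 is therefore estimated at 22 nM, between 8 nM and 65 nM.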

Compound 3, half-maximal inhibitory concentration: 21 nM
Estimate against measurement, compound 3: 1.0-fold (0.02 log units) above; measured number inside the range.
By their numbers in this assay, from the lowest: compounds 2, 3 and 1 (each within the scatter of the next).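

The position ortho to the methylsulfonyl group now also accepts a six-membered non-aromatic ring with a hetero atom: in this assay, the step of a 1.6-fold higher number from compound 2 to compound 3 (0.21 log units; within the scatter) stays small. Among these compounds, the step of a 1.0-fold lower number from compound 1 to compound 3 (0.02 log units; within the scatter) adds the first direct comparison of the two non-aromatic rings, and all three groups at this position now lie within the scatter. No available evidence bears on the basis of this result.

From the compounds shown here alone, it remains open whether this tolerance extends beyond six-membered rings. A smaller ring such as pyrrolidin-1-yl, an open-chain amine or a carboxylic acid could still separate from these values.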